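Isopropoxy to isopropylamino on the carbonyl carbon

A few compounds are considered here, and "the series" means these few. Any claim that something is new, unique, unknown or untested is made for them only; others in the source may bear on it.

Compound 1 `CC(C)OC(=O)NCCS(=O)(=O)NC(=O)c1ccc(Nc2nc(NC3(c4ccc(Cl)cc4)CC3)nc(OCC(F)(F)F)n2)cc1` gives 71 nm/s in a physicochemical assay for permeability, using PAMPA, at pH 7.4 (a lower number here means that the compound crosses the layer more slowly, a higher number that the compound crosses the layer faster), the second highest of the three numbers measured. Compound 2 `CC(C)(C)OC(=O)NCCS(=O)(=O)NC(=O)c1ccc(Nc2nc(NC3(c4ccc(Cl)cc4)CC3)nc(OCC(F)(F)F)n2)cc1` gives 111 nm/s and compound 3 `CC(C)S(=O)(=O)NC(=O)c1ccc(Nc2nc(NC3(c4ccc(Cl)cc4)CC3)nc(OCC(F)(F)F)n2)cc1` gives 31 nm/s. The step of a 1.6-fold higher number from compound 1 to compound 2 (0.19 log units; within the scatter) lies within the scatter, whereas the steps of a 2.3-fold lower number from compound 1 to compound 3 (0.36 log units; beyond the scatter) and a 3.6-fold lower number from compound 2 to compound 3 (0.55 log units; beyond the scatter) are modest and beyond it. Compound 4 `CC(C)NC(=O)NCCS(=O)(=O)NC(=O)c1ccc(Nc2nc(NC3(c4ccc(Cl)cc4)CC3)nc(OCC(F)(F)F)n2)cc1` differs from compound 1 by isopropylamino in place of isopropoxy on a carbonyl carbon. Going by the values given here, none of the measured steps tests this exchange: they vary other parts of the chain on the sulfonyl sulfur, not the carbonyl carbon. For compound 4 a modest lower number is expected in this assay, a 1.8-fold lower number from compound 1 to compound 4 (0.25 log units; within the scatter), smaller than or similar to a 2.3-fold lower number from compound 1 to compound 3 (0.36 log units; beyond the scatter). Compound 4 is therefore estimated at 40 nm/s, with a range of 18 nm/s to 90 nm/s.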

Compound 4, apparent permeability: 45 nm/s
Compound 4: the middle estimate sits 1.1-fold (0.05 log units) below what was measured; measured number inside the range.
By their numbers in this assay, from the lowest: compounds 3, 4, 1 and 2 (each within the scatter of the next, the first and the last beyond it).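

In this assay, isopropylamino in place of isopropoxy on a carbonyl carbon, with one hydrogen-bond donor entering and one hydrogen-bond acceptor leaving, gives a 1.6-fold lower number from compound 1 to compound 4 (0.20 log units; within the scatter). Compound 4 also stays close to the shorter isopropyl sulfonyl compound, with a 1.5-fold higher number from compound 3 to compound 4 (0.16 log units; within the scatter), and only the exchange for tert-butoxy clears the scatter, with a 2.5-fold lower number from compound 2 to compound 4 (0.39 log units; beyond the scatter). No supporting measurement accounts for these steps. Still open, going by these compounds, is whether tert-butylamino on the carbonyl carbon would match compound 2. A free amine or carboxylic acid at the end of the ethyl chain also remains to be read.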